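This account rests on a few compounds, and the source may have more. Where it says the series, first, only, none or still open, it means among the compounds named here.

Measured so far:
Compound 1 `CCCc1ccc(/C=C/C(=O)Nc2ccc3nc(CCC)cc(N)c3c2)cc1`: 3600 nM
Compound 2 `CCCc1cc(N)c2cc(NC(=O)/C=C/c3ccc(CC)cc3)ccc2n1`: 160 nM

For the measured compounds named here, in a functional assay on HEK293 cells for activation of melanin-concentrating hormone receptor 1 (Homo sapiens), read by inositol phosphate accumulation (on this read-out higher numbers stand for an effect only at larger amounts of compound and lower numbers for an effect already at smaller amounts), compound 2 stands lowest of the two numbers; the single measured step, a 23-fold lower number from compound 1 to compound 2 (1.35 log units; beyond the scatter), was a large one. Compound 3 `CCCc1cc(N)c2cc(NC(=O)/C=C/c3ccc(F)cc3)ccc2n1` is not yet measured. Going by the values given here, it differs from compound 2 by fluoro in place of ethyl on an aromatic carbon, so the change again falls on the ring where the only measured step sat. Among the compounds with values here, that step rewarded a shorter chain, but a fluorine is not a chain, and no measured pair shows what a fluorine does here. Compound 3 is therefore expected to move by a 1.9-fold higher number from compound 2 to compound 3 (0.27 log units; within the scatter), a small step within the scatter. Compound 3 is estimated at 300 nM, with a range from 80 nM to 1500 nM.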

Compound 3, half-maximal effective concentration: 200 nM
For compound 3 the middle estimate is 1.5-fold (0.18 log units) above the measured one, and the stated range covers the measured number.
By their numbers in this assay, from the lowest: compounds 2 and 3 (each within the scatter of the next); then compound 1.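

Putting fluoro in place of ethyl gives a 1.3-fold higher number from compound 2 to compound 3 (0.10 log units; within the scatter), so these two groups cannot be told apart at this position, even though one is a carbon chain and the other a single fluorine. Fluoro in place of propyl gives an 18-fold lower number from compound 1 to compound 3 (1.26 log units; beyond the scatter), which leaves propyl as the only one of the three groups that stands apart. Nothing shown gives a reason for this. Going by these compounds, whether a methyl group, a chloro group or a methoxy group would read like ethyl and fluoro stays open, as does the result with plain hydrogen here.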